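Swapping a Pyridine for an Imidazole on the Thioether Arm

This account rests on a few compounds, and the source may have more. Where it says the series, first, only, none or still open, it means among the compounds named here.

Of the compounds shown here, two built on the shared core have been measured in an assay on CHO cells for displacement of a labelled ligand from adenosine receptor A1 (Homo sapiens), read by scintillation counting, with a stated time of 90 min; on this read-out lower numbers stand for stronger inhibition and higher numbers for weaker inhibition. Compound 1 `N#Cc1c(N)nc(SCc2cccnc2)c(C#N)c1-c1ccc(OCC2CC2)cc1` gives 67 nM, the lowest of the two numbers. Compound 2 `CC(C)COc1ccc(-c2c(C#N)c(N)nc(SCC(N)=O)c2C#N)cc1` gives 603 nM, a markedly higher number that lies beyond the scatter. Going by the values given here, compound 2 differs from compound 1 in more than one place, so its two values show only that compound 1 binds more strongly; no single cause can be read from them.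

Compound 3 `N#Cc1c(N)nc(SCc2ncc[nH]2)c(C#N)c1-c1ccc(OCC2CC2)cc1` has not yet been measured. It differs from compound 1 in one place: 1H-imidazol-2-yl in place of pyridin-3-yl on a saturated chain carbon bound to a sulfur. In words, 1H-imidazol-2-yl takes the place of pyridin-3-yl on a saturated chain carbon bound to a sulfur. Among the compounds with values here, no measured pair in this set makes that change, so there is nothing to lean on beyond the value of compound 1 itself. Because compound 1 gives 67 nM, the expected result for compound 3 is a number near it. The expected step is a 1.5-fold higher number from compound 1 to compound 3 (0.17 log units; within the scatter), small and not clearly beyond the scatter in either direction. Compound 3 is estimated at 100 nM, with a range from 30 nM to 400 nM.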

Compound 3, inhibition constant: 235 nM
Compound 3: middle estimate off by 2.4-fold (0.37 log units), on the low side, and the stated range covers the measured number.
By their numbers in this assay, from the lowest: compound 1; then compound 3; then compound 2.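

Read in this assay, 1H-imidazol-2-yl in place of pyridin-3-yl on a saturated chain carbon bound to a sulfur gives a 3.5-fold higher number from compound 1 to compound 3 (0.54 log units; beyond the scatter), a modest change but one beyond the usual scatter. Going by these compounds alone, this is the first comparison here that differs in one place only, so unlike the gap between compound 1 and compound 2, it shows that the ring on this arm alone can shift the number, and that this imidazole ring binds more weakly than the pyridine ring. Nothing measured on these compounds accounts for the shift, and the swap alters several things at once: the ring goes from six-membered to five-membered, the count of hetero atoms rises, and a hydrogen-bond donor enters.

A phenyl ring or a 1-methyl-1H-imidazol-2-yl group at this place could help separate those features, and the compounds shown leave open which of them matters. Also open, on these data alone, is how a longer chain between the sulfur and the ring, or an amine in place of the ring, would read in this assay.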